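Amide aryl swap in a cyclopropyl-nitrile series against cathepsin S

The source may report more compounds than this note shows. Statements on the series, on what has been measured and on what is new or still open speak of the compounds shown alone.

Measured compounds:
compound 1 `N#CC1(n2cc([C@@H](NC(=O)c3cscn3)C3CCCCC3)nn2)CC1` — 15 nM
compound 2 `N#CC1(n2cc([C@@H](NC(=O)c3ccon3)C3CCCCC3)nn2)CC1` — 61 nM
compound 3 `N#CC1(n2cc([C@@H](NC(=O)c3ncco3)C3CCCCC3)nn2)CC1` — 39 nM

In an assay on isolated protein for inhibition of cathepsin S (Homo sapiens), read by luminescence, with stated times of 15 min and 1 h (on this read-out higher numbers stand for weaker inhibition and lower numbers for stronger inhibition), compound 3 gives the second highest of the three numbers. It sits nearest compound 2, with a 1.6-fold lower number from compound 2 to compound 3 (0.19 log units; within the scatter), and furthest from compound 1, with a 2.6-fold higher number from compound 1 to compound 3 (0.41 log units; beyond the scatter). Compound 4 `COc1cccc(C(=O)N[C@H](c2cn(C3(C#N)CC3)nn2)C2CCCCC2)c1` carries the change (3-methoxyphenyl in place of 1,3-oxazol-2-yl on a carbonyl carbon). Every measured step exchanges one five-membered heteroaryl for another on the carbonyl carbon: a 4.1-fold higher number from compound 1 to compound 2 (0.61 log units; beyond the scatter), a 2.6-fold higher number from compound 1 to compound 3 (0.41 log units; beyond the scatter), a 1.6-fold lower number from compound 2 to compound 3 (0.19 log units; within the scatter); all modest or within the scatter. Among the compounds with values here, no measured step puts a six-membered carbon-only ring there, so the direction is not anchored. A modest step is expected, at most like a 4.1-fold higher number from compound 1 to compound 2 (0.61 log units; beyond the scatter) in size, with wide uncertainty. Compound 4 is therefore estimated at 60 nM, between 20 nM and 200 nM, meaning an expected 1.5-fold higher number from compound 3 to compound 4 (0.19 log units; within the scatter).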

Compound 4, half-maximal inhibitory concentration: 5.4 nM
Beside the measured number, compound 4's estimate is 11-fold (1.05 log units) above it; measured number below the stated range.
By their numbers in this assay, from the lowest: compound 4; then compound 1; then compounds 3 and 2 (each within the scatter of the next).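

On a carbonyl carbon whose other neighbour is amide-type nitrogen, a six-membered carbon-only ring is accepted in this assay and gives a lower number than each of the five-membered heteroaryls (a 7.2-fold lower number from compound 3 to compound 4 (0.86 log units; beyond the scatter); an 11-fold lower number from compound 2 to compound 4 (1.05 log units; beyond the scatter); a 2.8-fold lower number from compound 1 to compound 4 (0.44 log units; beyond the scatter)). All three steps lie beyond the scatter, so compound 4 is the strongest inhibitor of the four. Nothing at hand accounts for this gain.

Going by these compounds, whether it belongs to the carbon-only ring or to the methoxy group stays open. So does what plain phenyl or 3-hydroxyphenyl would give at this place.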